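A Dichlorophenyl Swap Within a Weakly Active Triazole Series

A few compounds are considered here, and "the series" means these few. Any claim that something is new, unique, unknown or untested is made for them only; others in the source may bear on it.

The study concerns three spirocyclic compounds sharing one core and differing only in the aryl group carried on a five-membered aromatic ring with three nitrogen atoms. Compound 1 `N#CC1=C(N)Oc2c(c3nc4ccccc4nc3c3ccccc23)C12C(=O)N(Cc1cnnn1-c1cccc(Cl)c1)c1ccccc12` carries a 3-chlorophenyl group there, compound 2 `N#CC1=C(N)Oc2c(c3nc4ccccc4nc3c3ccccc23)C12C(=O)N(Cc1cnnn1-c1ccc(Br)cc1)c1ccccc12` a 4-bromophenyl, and compound 3 `N#CC1=C(N)Oc2c(c3nc4ccccc4nc3c3ccccc23)C12C(=O)N(Cc1cnnn1-c1ccc(S(N)(=O)=O)cc1)c1ccccc12` a 4-sulfamoylphenyl. All three were tested in a functional assay on HepG2 cells (Homo sapiens) for antiproliferative activity, read by MTT assay, with a stated time of 48 h; on this read-out lower numbers stand for stronger inhibition and higher numbers for weaker inhibition. Compound 1 reaches only the limit of the assay, > 50000 nM. Compound 2 likewise gives only the limit, > 50000 nM. Compound 3 gives a number, 42200 nM. The step that the two limits leave unreadable from compound 1 to compound 2 is therefore unreadable, while an at least 1.1-fold lower number from compound 1 to compound 3 (0.07 log units; that floor lies within the scatter) and an at least 1.1-fold lower number from compound 2 to compound 3 (0.07 log units; that floor lies within the scatter) are floors lying within the scatter. Two of the three values sit at the limit of > 50000 nM in this assay, at which 2 of the 3 values shown sit, and compound 2 stands among them: nothing separates it from compound 1, and its gap to compound 3 cannot be read beyond the scatter.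

Compound 4 `N#CC1=C(N)Oc2c(c3nc4ccccc4nc3c3ccccc23)C12C(=O)N(Cc1cnnn1-c1cc(Cl)ccc1Cl)c1ccccc12` is the next member: 2,5-dichlorophenyl in place of 4-bromophenyl on an aromatic nitrogen. Going by the values given here, no measured step involves a 2,5-dichlorophenyl group, and the one halogen swap measured, a step that the two limits leave unreadable from compound 1 to compound 2, returned no readable number. Nothing in these data points to a step beyond the scatter, so compound 4 is expected to stay at or near the limit. The expected step is a step that the limit leaves unreadable from compound 2 to compound 4. Compound 4 is estimated at 60000 nM, between 30000 nM and 150000 nM.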

Compound 4, half-maximal inhibitory concentration: > 50000 nM
Compound 4: no number, only a limit (the forecaster's own chance of this, stated with the estimate: 70%); the middle value does not contradict the limit.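

In this assay, adding a second chlorine to the aryl group on the aromatic nitrogen, as in the 2,5-dichlorophenyl group of compound 4, still yields no number, and the steps to compound 4 from compound 1 and from compound 2 cannot be read. Going by these compounds alone, the only step with a readable floor is an at least 1.1-fold higher number from compound 3 to compound 4 (0.07 log units; that floor lies within the scatter), so these data do not set the 4-sulfamoylphenyl group of compound 3 apart from the 2,5-dichlorophenyl group of compound 4. With compound 4 added, all three halogen-bearing aryl groups shown, in compound 1, compound 2 and compound 4, end at the same assay limit: the limit of > 50000 nM in this assay, at which 3 of the 4 values shown sit.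

As far as these compounds go, whether any group at this position can give a value clearly beyond the scatter from these limits remains open. A 4-aminophenyl or a 4-carboxyphenyl group on the same nitrogen would be one way to test this, and the compounds shown do not tell whether the aryl group or the shared core sets the level of this series.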